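The source may hold more compounds than are shown below. What is called first, only, known or untested is meant among the compounds shown, and "the series" means these compounds.

Working notes on the series. In a functional assay on NCI-H1299 cells (Homo sapiens) for inhibition, read by CCK-8 assay, with a stated time of 72 h, tested at 10 uM (on this read-out lower numbers stand for less inhibition of growth and higher numbers for more inhibition of growth at the one concentration tested), compound 2 `CN(C)C(=O)c1cc2cnc(Nc3ccc(NC(=O)C4(C(=O)Nc5ccc(O)cc5)CC4)cc3)nc2n1C1CCCC1` gives 89.7% as its reading, and compound 1 `CN(C)C(=O)c1cc2cnc(Nc3ccc(NC(=O)C4(C(=O)Nc5ccc(Cl)cc5)CC4)cc3)nc2n1C1CCCC1` gives 88.6% as its reading. Within the data shown here, these two values lie within the scatter of each other, so compound 2 stands level with the only other measured compound and neither can be ranked.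

The next compound is compound 3 `CN(C)C(=O)c1cc2cnc(Nc3ccc(NC(=O)C4(C(=O)Nc5ccccc5)CC4)cc3)nc2n1C1CCCC1` and the change is hydrogen in place of hydroxy on an aromatic carbon in the structure, with hydrogen in place of hydroxy on an aromatic carbon. Among the measured compounds shown here, one measured step bears on this place: a number 1.1 percentage points higher from compound 1 to compound 2 (within the scatter) for hydroxy in place of chloro on that same aromatic carbon. For the measured compounds named here, that is a single small step, and it shows only that these two groups give readings within the scatter. Going by the values given here, no compound with hydrogen at this place has been measured, so the range stays wide. Going by that step alone, the expected result in this assay is a number 2.7 percentage points lower from compound 2 to compound 3 (within the scatter) and so no step beyond the scatter. The estimate for compound 3 is 87% as a middle value, with an expected range from 75% to 96% on this read-out.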

Compound 3, percent growth inhibition at one concentration: 90.5%
Estimate against measurement, compound 3: 3.5 percentage points below; the measured number falls inside the stated range.
By their numbers in this assay, from the lowest: compounds 1, 2 and 3 (each within the scatter of the next).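

With hydrogen now in place on this aromatic carbon, para to a large group, the change in this assay reads as a number 0.8 percentage points higher from compound 2 to compound 3 (within the scatter) for hydrogen in place of hydroxy and as a number 1.9 percentage points higher from compound 1 to compound 3 (within the scatter) for hydrogen in place of chloro. The series thus gains its plain phenyl reference, and at this single concentration neither hydroxy nor chloro can be told apart from hydrogen, so the position shows no dependence on any of the three. No measurement at hand accounts for this level reading.

From the compounds shown here alone, it remains open whether a carboxylic acid, an aminomethyl group or a methoxy group on this same carbon would also stay within the scatter, or whether one of them would finally move the reading at this position. Going by these compounds, it also remains open whether compounds that read level at one concentration would stay level across a full concentration series, since a single-point reading of growth inhibition cannot settle that for hydrogen, hydroxy or chloro.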